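This account rests on a few compounds, and the source may have more. Where it says the series, first, only, none or still open, it means among the compounds named here.

Measured in a functional assay on U2OS cells (Homo sapiens) for cytotoxicity, read by MTT assay, with a stated time of 48 h; a higher number here means a weaker inhibitor, a lower number a stronger inhibitor:
- compound 1 `Fc1cccc(Nc2nc(-c3cccc(F)c3)nc3ccc(F)cc23)c1`: 49600 nM
- compound 2 `Oc1ccccc1Nc1nc(-c2cccc(F)c2)nc2ccc(F)cc12`: 41400 nM
- compound 3 `Nc1cccc(Nc2nc(-c3cccc(F)c3)nc3ccc(F)cc23)c1`: 49700 nM

The three compounds share one core and differ only in the group they carry, and their values lie within the scatter of one another. Compound 3 therefore has no distinct rank: it stands level with its two neighbours, at a 1.0-fold higher number from compound 1 to compound 3 (0.00 log units; within the scatter) and a 1.2-fold higher number from compound 2 to compound 3 (0.08 log units; within the scatter).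

The next compound, compound 4 `Cc1ccccc1Nc1nc(-c2cccc(F)c2)nc2ccc(F)cc12`, has 2-methylphenyl in place of 3-aminophenyl on a nitrogen on an aromatic ring. Among the measured compounds shown here, no measured step makes this exact change, so the evidence is indirect. The nearest comparisons are the other exchanges of the same group. These are a 1.2-fold lower number from compound 1 to compound 2 (0.08 log units; within the scatter), together with the two steps to compound 3 already given, and none of them rises above the scatter. Replacing 3-fluorophenyl, 2-hydroxyphenyl or 3-aminophenyl has so far left this assay essentially unmoved, so no shift beyond the scatter is expected here, in either direction.

The expected change is small, a 1.1-fold lower number from compound 3 to compound 4 (0.04 log units; within the scatter). For compound 4 the estimated value is 45000 nM, with an expected range from 22000 nM to 90000 nM.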

Compound 4, half-maximal inhibitory concentration: > 50000 nM
Compound 4: no number, only a limit; the forecaster's own chance of this, stated with the estimate: 15%; middle value at least 1.1-fold (0.04 log units) away from the limit.
By their numbers in this assay, from the lowest: compounds 2, 1 and 3 (each within the scatter of the next). At a limit, above all of these: compound 4.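

In this assay compound 4 gives > 50000 nM, which is a limit and not a number, and 2-methylphenyl in place of 3-aminophenyl gives a number no lower from compound 3 to compound 4 (the limit leaves the size open), with 2-methylphenyl the first group on this nitrogen to reach the limit of the assay: the limit of > 50000 nM in this assay, at which 1 of the 4 values shown sits.

Among the compounds shown here, the one step with a readable floor is the exchange of hydroxy for methyl on an aromatic carbon, an at least 1.2-fold higher number from compound 2 to compound 4 (0.08 log units; that floor lies within the scatter), and that floor does not establish a real separation between the two compounds. 2-Methylphenyl in place of 3-fluorophenyl gives a number no lower from compound 1 to compound 4 (the limit leaves the size open). This step and the step from 3-aminophenyl cannot be read, so the change from 3-aminophenyl, which has a hydrogen-bond donor and acceptor, to 2-methylphenyl, which has neither, can be said only to give no lower number.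

Going by these compounds, it remains open how far the true value of compound 4 lies from its limit, and so whether 2-methylphenyl differs at all from the other groups. On these data alone, it is also open whether a carboxylic acid, a morpholine or a longer chain on this nitrogen would bring any number beyond the scatter of those seen here.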